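This account rests on a few compounds, and the source may have more. Where it says the series, first, only, none or still open, it means among the compounds named here.

In an ADME assay on MRC5 cells (Homo sapiens) for antiproliferative activity, read by fluorescence and resazurin assay, with a stated time of 68 h (a lower number here means that less compound is needed, a higher number that more compound is needed for the effect), compound 3 (`Cc1cc(Nc2cc(C(=O)NCCN3CCCC3)c3cc(F)ccc3n2)on1`) gives > 50000 nM, which is a limit of the assay and not a number. Compound 1 (`Cc1ccc(-c2cc(C(=O)Nc3cccnc3)c3ccccc3n2)cc1`) gives > 50000 nM, which is also a limit. For the measured compounds named here, compound 2 (`Cc1ccc(-c2cc(C(=O)NCCCN(C)C)c3cc(Cl)ccc3n2)cc1`) gives 6000 nM, the only true number so far. Compound 3 therefore stands at the limit of > 50000 nM in this assay, at which 2 of the 3 values shown sit.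

Compound 4 (`O=C(NCCN1CCCC1)c1cc(N2CCn3ccnc3C2)nc2ccc(F)cc12`) differs from compound 3 in one place: a group of 9 heavy atoms (6 carbon, 3 nitrogen; one five-membered aromatic ring with 2 hetero atoms, one six-membered non-aromatic ring with 2 hetero atoms) in place of a group of 7 heavy atoms (4 carbon, 2 nitrogen, 1 oxygen; one five-membered aromatic ring with 2 hetero atoms), on an aromatic carbon. The change lies on an aromatic carbon, next to the ring nitrogen, and the rest of the structure stays the same.

Going by the values given here, no measured pair shows a change at this place, so the expectation rests only on these three values. A small step toward a lower number is expected in this assay, or none beyond the scatter, and another limit is a likely outcome. The estimated move is an at least 1.4-fold lower number from compound 3 to compound 4 (0.15 log units; that floor lies within the scatter). For compound 4 the estimate is 35000 nM, with an expected range of 10000 nM to 50000 nM.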

Compound 4, half-maximal effective concentration: > 50000 nM
Compound 4 ended at the assay's limit; the forecaster's own chance of this, stated with the estimate: 60%; middle value at least 1.4-fold (0.15 log units) from the limit.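

For the compounds shown here, compound 3 and compound 4 both end at a limit in this assay and not at a number, so no step between them can be read: the limit of > 50000 nM in this assay, at which 3 of the 4 values shown sit. The compounds shown leave open whether any group at this place on the shared core gives a measurable value.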